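The compounds below may be only part of what the source reports. "The series", "measured", "known", "first", "only" and "open" are said of these compounds alone.

Going by the values given here, the series shares one amide-linked sugar headgroup, and the three measured members differ in the group attached to the amide carbonyl. Compound 1 `CC(C)c1ccc(C[C@H](C)C(=O)N[C@@H]2O[C@H](CO)[C@@H](O)[C@H](O)[C@H]2O)cc1` gives 0.143 in a physicochemical assay for lipophilicity, measured as octanol-water partition; a lower number here means a more polar compound, a higher number a more lipophilic compound. Compound 2 `O=C(C[C@H]1CC(=O)c2c(F)cc(F)cc21)N[C@@H]1O[C@H](CO)[C@@H](O)[C@H](O)[C@H]1O` gives -1.21 in this assay. Compound 3 `Cc1ccc(-c2cnc(CCC(=O)N[C@@H]3O[C@H](CO)[C@@H](O)[C@H](O)[C@H]3O)o2)cc1` gives -0.574 in this assay, the second highest of the three numbers: it sits beyond the scatter below compound 1 and beyond the scatter above compound 2. Compound 4 `O=C(CCc1ncc(-c2ccccc2)o1)N[C@@H]1O[C@H](CO)[C@@H](O)[C@H](O)[C@H]1O` has not yet been measured. It differs from compound 3 in one place: hydrogen in place of methyl on an aromatic carbon, that is, 4-methylphenyl becoming phenyl. Among the compounds with values here, no measured pair shows this change, so the expectation rests on the change alone: from compound 3 to compound 4 a step of a number 0.48 log units lower from compound 3 to compound 4 (beyond the scatter) in this assay is expected, downward and beyond the scatter. Compound 4 is therefore estimated at -1.05, within a range of -1.5 to -0.6.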

Compound 4, partition coefficient: -0.915
The estimate for compound 4 lay 0.14 log units below the measured number, within the range that was stated.
By their numbers in this assay, from the lowest: compounds 2 and 4 (each within the scatter of the next); then compound 3; then compound 1.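

Hydrogen in place of methyl on the aromatic carbon, 4-methylphenyl becoming phenyl, gives in this assay a number 0.34 log units lower from compound 3 to compound 4 (beyond the scatter), the first reading of a change at one place in this series. It shows that the methyl at this position counts in the read-out, with the number falling once it leaves. Nothing among the data gives a reason for the size of this step.

Open, going by these compounds, is how an ethyl group, a methoxy group, an amine or a carboxylic acid at this position would read. Also open is whether the same change gives a similar step elsewhere in the series, as the compounds shown hold only this one pair.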